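Isobutoxycarbonyl for cyclopropylmethyl on the ring nitrogen

The source may hold more compounds than are shown below. What is called first, only, known or untested is meant among the compounds shown, and "the series" means these compounds.

Measured so far in an assay on HEK293 cells for inhibition of acid ceramidase (Rattus norvegicus), read by LC-MS, with a stated time of 30 min; a lower number here means a stronger inhibitor, a higher number a weaker inhibitor:
compound 1, `CCCCCCNC(=O)n1cc(N(C)Cc2ccccc2)c(=O)[nH]c1=O`, gives 5500 nM
compound 2, `CCCCCCNC(=O)n1cc(F)c(=O)n(CC2CC2)c1=O`, gives 61 nM

Compound 2 gives the lower of the two numbers in this assay, and its gap to compound 1 lies beyond the scatter. Compound 3, `CCCCCCNC(=O)n1cc(F)c(=O)n(C(=O)OCC(C)C)c1=O`, carries isobutoxycarbonyl in place of cyclopropylmethyl on an aromatic nitrogen. Within the data shown here, no measured pair shows this change, so its size is not known from the series. The expectation for compound 3 is a step from compound 2 of a 2.0-fold higher number from compound 2 to compound 3 (0.29 log units; within the scatter), a mild weakening that may still fall within the scatter. Compound 3 is estimated at 120 nM, with a range from 30 nM to 500 nM.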

Compound 3, half-maximal inhibitory concentration: 16 nM
Beside the measured number, compound 3's estimate is 7.5-fold (0.88 log units) above it, outside the stated range (below it).
By their numbers in this assay, from the lowest: compound 3; then compound 2; then compound 1.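

Replacing cyclopropylmethyl with isobutoxycarbonyl on the ring nitrogen gives a 3.8-fold lower number from compound 2 to compound 3 (0.58 log units; beyond the scatter) in this assay and shows that this nitrogen accepts a bulkier group with no ring. The three-membered ring of compound 2 is therefore not needed for a low number here, and a substituent with a carbonyl and two hydrogen-bond acceptors is accepted. Nothing on hand explains the gain.

On these data alone, whether it follows the carbonyl or the branched alkyl part stays open. A plain isobutyl group or a carbamoyl group on this nitrogen would separate the two.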